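Benzamide in place of propylurea: Vero cytotoxicity outlook

This account rests on a few compounds, and the source may have more. Where it says the series, first, only, none or still open, it means among the compounds named here.

Compound 1 `CCCNC(=O)Nc1cc2nc(C3CCCCC3)[nH]c2cc1N1CCCC1` has been tested in an ADME assay on Vero cells (Chlorocebus sabaeus) for cytotoxicity, read by resazurin assay, with a stated time of 3 days; a higher number here means a weaker inhibitor, a lower number a stronger inhibitor. There compound 1 gives only a limit of > 100 ug/mL. Compound 3 `CCCNC(=O)Nc1cc2nc(C3CCCCC3)[nH]c2cc1N(CC)CC` likewise returns only a limit of > 100 ug/mL. The step that the two limits leave unreadable from compound 1 to compound 3 is therefore not readable. Compound 2 `CN(C)c1cc2[nH]c(C3CCCCC3)nc2cc1NC(=O)c1ccc(C(C)(C)C)cc1`, which carries an amide on the shared core, also gives only a limit of > 100 ug/mL. All three values sit at the limit of > 100 ug/mL in this assay, at which 3 of the 3 values shown sit.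

Compound 4 `O=C(Nc1cc2nc(C3CCCCC3)[nH]c2cc1N1CCCC1)c1ccccc1` differs from compound 1 in one place: phenyl in place of propylamino on a carbonyl carbon. Among the compounds with values here, no measured step follows this change directly. Within the data shown here, the single measured step, from compound 1 to compound 3, cannot be sized, and every value in this assay is a limit, so no direction can be read and no step beyond the scatter is expected.

Compound 4 is expected to give about 150 ug/mL in this assay, estimated from 60 ug/mL to 400 ug/mL. The step this estimate means is a step that the limit leaves unreadable from compound 1 to compound 4, an expectation only, most likely reported again as a limit.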

Compound 4, half-maximal inhibitory concentration: > 100 ug/mL
Compound 4: a limit, no number; the forecaster's own chance of this, stated with the estimate: 75%; the middle value lies beyond the limit too.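

Compound 1 and compound 4 both return only a limit in this assay, so no step can be read between them: the limit of > 100 ug/mL in this assay, at which 4 of the 4 values shown sit.

The compounds shown leave open whether phenyl in place of propylamino on a carbonyl carbon changes cytotoxicity at all.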